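The compounds below may be only part of what the source reports. "The series", "measured", "known", "first", "only" and "open" are said of these compounds alone.

Series notes. Compound 1 `CCOc1nc2cccc(C(=O)Nc3ccc(F)cc3)c2n1Cc1ccc(-c2ccccc2-c2nnn[nH]2)cc1` and compound 2 `CCOc1nc2cccc(C(=O)Nc3ccc(OC)cc3)c2n1Cc1ccc(-c2ccccc2-c2nnn[nH]2)cc1` share the same core and differ only in the aromatic ring carried on the amide-type nitrogen. In an assay on isolated protein for inhibition of NEDD8-activating enzyme E1 regulatory subunit (Homo sapiens), read by Western blot, with stated times of 10 min and 30 min, tested at 25 uM (on this read-out higher numbers stand for more inhibition at the one concentration tested (going by the name of the read-out) and lower numbers for less inhibition), compound 1 gives 45.3% and compound 2 gives 25.8%. Among the measured compounds shown here, the single step measured so far, a number 19.5 percentage points lower from compound 1 to compound 2 (beyond the scatter), is the only change examined at this ring. On the two numbers available compound 2 stands lowest, with compound 1 as its nearest neighbour, higher by a margin beyond the scatter.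

Compound 3 `CCOc1nc2cccc(C(=O)Nc3ccncc3)c2n1Cc1ccc(-c2ccccc2-c2nnn[nH]2)cc1` takes the step (pyridin-4-yl in place of 4-methoxyphenyl on an amide-type nitrogen). For the measured compounds named here, no measured step bears directly on this exchange. Going by the values given here, the one step at this nitrogen, a number 19.5 percentage points lower from compound 1 to compound 2 (beyond the scatter), traded one substituted phenyl for another, whereas here the six-membered aromatic ring of carbon only gives way to a six-membered aromatic ring with one hetero atom. That step does show the read-out moving by a modest amount at this position, so a move of comparable size in either direction would not surprise. Among the compounds with values here, with no closer precedent, compound 3 in this assay is expected to show a step of a number 4.2 percentage points higher from compound 2 to compound 3 (within the scatter). The estimate for compound 3 is therefore 30%, with a range from 12% to 50%.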

Compound 3, a percentage reported as inhibition, at one concentration (the size of the read-out at that concentration, not a potency): 39.8%
For compound 3 the middle estimate is 9.8 percentage points below the measured one; the measured number falls inside the stated range.
By their numbers in this assay, from the lowest: compound 2; then compounds 3 and 1 (each within the scatter of the next).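

At the amide-type nitrogen, the ring need not be a substituted six-membered aromatic ring of carbon only: in this assay, a number 14 percentage points higher from compound 2 to compound 3 (beyond the scatter) shows that pyridin-4-yl in place of 4-methoxyphenyl recovers a modest amount of the read-out. Against the 4-fluorophenyl ring, the exchange gives a number 5.5 percentage points lower from compound 1 to compound 3 (within the scatter), so pyridin-4-yl and 4-fluorophenyl cannot be told apart here, and among these three compounds only compound 2, with its 4-methoxyphenyl, stands apart from the other two by more than the scatter. No available evidence accounts for this ordering, so the three numbers record the differences without explaining them.

The three compounds leave open whether the read-out at this position follows the 4-methoxyphenyl ring specifically or would shift in the same way with other groups, such as an amine or a carboxylic acid on the ring, or a longer chain in its place. With a single tested concentration and inhibition well short of complete for all three, the read-out also leaves open how these compounds would rank in potency.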